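Swapping the indole group of compound 3

The source may hold more compounds than are shown below. What is called first, only, known or untested is meant among the compounds shown, and "the series" means these compounds.

Compound 1 `Cn1c(=O)c(S(=O)(=O)c2ccccc2)cc2cnc(Nc3cnc4[nH]ccc4c3)nc21`: 5000 nM
Compound 2 `Cc1ccc(S(=O)(=O)c2cc3cnc(Nc4cnc5c(c4)CC(=O)N5)nc3n(C)c2=O)cc1`: 15000 nM
Compound 3 `Cc1ccc(S(=O)(=O)c2cc3cnc(Nc4ccc5cc[nH]c5c4)nc3n(C)c2=O)cc1`: 15000 nM

In a functional assay on K562 cells (Homo sapiens) for inhibition, read by trypan blue exclusion, with a stated time of 72 h (a higher number here means a weaker inhibitor, a lower number a stronger inhibitor), compound 3 reads 15000 nM and stands level with compound 2 at the top of the three numbers, with compound 1 lower. Compound 4 `Cc1ccc(S(=O)(=O)c2cc3cnc(Nc4cnc5[nH]ccc5c4)nc3n(C)c2=O)cc1` changes one group of compound 3: a group of 9 heavy atoms (7 carbon, 2 nitrogen; one five-membered aromatic ring with 1 hetero atom, one six-membered aromatic ring with 1 hetero atom) in place of a group of 9 heavy atoms (8 carbon, 1 nitrogen; one five-membered aromatic ring with 1 hetero atom, one six-membered aromatic ring of carbon only), on a nitrogen on an aromatic ring. Going by the values given here, the only measured step of this kind, no change at the digits printed from compound 2 to compound 3 (within the scatter), also swaps the group on that nitrogen and moved nothing. Compound 1 already carries the entering group on a core that differs elsewhere, and compound 1 reads 5000 nM in this assay. A small move towards stronger inhibition is therefore expected, possibly none beyond the scatter: the expected change is a 1.5-fold lower number from compound 3 to compound 4 (0.18 log units; within the scatter). The estimate for compound 4 is 10000 nM, with an expected range of 4500 nM to 20000 nM.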

Compound 4, half-maximal inhibitory concentration: 15000 nM
Compound 4: middle estimate off by 1.5-fold (0.18 log units), on the low side; measured number inside the range.
By their numbers in this assay, from the lowest: compound 1; then compounds 2, 3 and 4 (each within the scatter of the next).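

In this assay the swap on this nitrogen gives no change at the digits printed from compound 3 to compound 4 (within the scatter) and no change at the digits printed from compound 2 to compound 4 (within the scatter) so the three groups shown here do not separate on this core. Going by these compounds alone, the one step beyond the scatter is methyl in place of hydrogen on an aromatic carbon, with a 3.0-fold higher number from compound 1 to compound 4 (0.48 log units; beyond the scatter) as its size, so the gap to compound 1 lies with that methyl rather than with the group on the nitrogen. Nothing measured here accounts for either result. As far as these compounds go, whether these groups would separate on the core of compound 1 stays open. So does the effect of a methoxy group or chlorine in place of that methyl.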